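A few compounds are considered here, and "the series" means these few. Any claim that something is new, unique, unknown or untested is made for them only; others in the source may bear on it.

Compound 1 `CCCCNc1c(C#N)c(NCCCC)c2c(N)nc(N)nc2c1Cl` and compound 2 `CCCCNc1c(C#N)c(NCCCC)c2c(N)nc(N)nc2c1F` share one core and differ in a single place: fluoro in place of chloro on an aromatic carbon. In a functional assay on A549 cells (Homo sapiens) for cytotoxicity, read by MTT assay (a higher number here means a weaker inhibitor, a lower number a stronger inhibitor), compound 1 gives 2 ug/mL. For compound 2 this assay reports only a limit, > 1000 ug/mL. The step is an at least 500-fold higher number from compound 1 to compound 2 (2.69 log units; beyond the scatter), a figure that rests on (the limit of > 1000 ug/mL in this assay, at which 2 of the 3 values shown sit). Compound 3 `N#Cc1c(NCc2ccccc2)c(Cl)c2nc(N)nc(N)c2c1NCc1ccccc1` has a different core, and the difference between the two cores is not broken down here. For compound 3 this assay likewise reports only a limit, > 1000 ug/mL. Compound 4 `N#Cc1c(NCc2ccccc2)c(F)c2nc(N)nc(N)c2c1NCc1ccccc1`, not yet measured, differs from compound 3 by fluoro in place of chloro on an aromatic carbon, the same kind of change as before, the surroundings now being ortho to a benzylamino group and para to a benzylamino group rather than a butylamino group. The step is expected to be a number no higher from compound 3 to compound 4 (the limit leaves the size open), because compound 3 already stands at the limit of > 1000 ug/mL in this assay, at which 2 of the 3 values shown sit. Compound 4 is therefore estimated at 1000 ug/mL.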

Compound 4, half-maximal inhibitory concentration: 13.9 ug/mL
Estimate against measurement, compound 4: 72-fold (1.86 log units) above; the measured number lies below the stated range.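

Fluoro in place of chloro on an aromatic carbon gives an at least 71-fold lower number from compound 3 to compound 4 (1.85 log units; beyond the scatter) in this assay, the opposite direction to the step between the butylamino compounds, and the two steps differ: the same change on two cores in this assay, an at least 500-fold higher number (2.69 log units; beyond the scatter) from compound 1 to compound 2 and an at least 71-fold lower number (1.85 log units; beyond the scatter) from compound 3 to compound 4, at least 35000-fold (4.55 log units) apart, beyond the scatter of two such steps. The change therefore does not carry over in direction or size between these two cores, and its effect on one core cannot be taken as a guide to the other. Each step rests on a limit, so neither true size is known, and two pairs cannot show which difference between the cores reverses the direction: the limit of > 1000 ug/mL in this assay, at which 2 of the 4 values shown sit.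

The compounds shown leave open how a bromo group in the same place would stand. They also leave open whether a longer chain on the amino groups, such as hexylamino, would follow compound 1 or compound 3.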